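The source may hold more compounds than are shown below. What is called first, only, known or untested is meant among the compounds shown, and "the series" means these compounds.

Working notes on the series. Of the compounds shown here, three are measured so far: compound 1 `CCCSc1nc(N/N=C(\C)c2ccccc2O)c2nnn(Cc3ccccc3Cl)c2n1`, compound 2 `CCCSc1nc(N/N=C/c2cc(OC)c(OC)c(OC)c2)c2nnn(Cc3ccccc3)c2n1` and compound 3 `CCCSc1nc(N/N=C/c2cccnc2)c2nnn(Cc3ccccc3)c2n1`. In a functional assay on ECa-109 cells (Homo sapiens) for antiproliferative activity, read by MTT assay, with a stated time of 72 h (a higher number here means a weaker inhibitor, a lower number a stronger inhibitor), compound 2 gives 4060 nM. For compound 1 the result is only a limit of the assay, > 64000 nM. For compound 3 likewise only a limit is reported, > 64000 nM. Compound 3 thus stands at the limit of > 64000 nM in this assay, at which 2 of the 3 values shown sit, and no number for it is known; compound 2 alone returns a number. Among the compounds with values here, no pair of measured compounds differing in one place exists in this set, so no measured step is available.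

Compound 4 `CCCSc1nc(N/N=C/c2cccc(Cl)c2)c2nnn(Cc3ccccc3)c2n1` is the next to be measured. It differs from compound 3 in one place: 3-chlorophenyl in place of pyridin-3-yl on a carbon with a double bond to nitrogen. Within the data shown here, no measured pair shows what such a change does in this assay, and the one compound with a number, compound 2, differs from compound 3 in more than one place. The expectation for compound 4 is therefore weakly held: a step of size an at least 2.1-fold lower number from compound 3 to compound 4 (0.32 log units; beyond the scatter) is expected in this assay, toward a stronger inhibitor, though a result within the scatter of the limit is nearly as likely. Compound 4 is expected at 30000 nM, within 8000 nM to 64000 nM, with a real chance that only a limit is returned again.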

Compound 4, half-maximal inhibitory concentration: > 64000 nM
Compound 4 was reported as a limit; the forecaster's own chance of this, stated with the estimate: 50%; middle value at least 2.1-fold (0.32 log units) away from the limit.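

In this assay compound 4 gives > 64000 nM as a limit and not a number. In this assay, within the data shown here, compound 3 gives > 64000 nM as a limit too, so no step between compound 3 and compound 4 can be read. The compounds shown leave open what 3-chlorophenyl in place of pyridin-3-yl does to antiproliferative activity.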